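The compounds below may be only part of what the source reports. "The series", "measured", "known", "first", "only" and "open" are said of these compounds alone.

Measured in a functional assay on A549 cells (Homo sapiens) for cytotoxicity, read by MTT assay, with a stated time of 72 h; on this read-out lower numbers stand for stronger inhibition and higher numbers for weaker inhibition:
- compound 1 `CCCN1CCN(CCCCn2c3c(c4ccccc42)C(=O)c2c[n+]([O-])c4ccccc4c2C3=O)CC1`: 320 nM
- compound 2 `CN1CCN(CCCn2c3c(c4ccccc42)C(=O)c2c[n+]([O-])c4ccccc4c2C3=O)CC1`: 140 nM

Compound 2 has the lower of the two numbers, so it is the stronger of this pair. Compound 3 `O=C1c2c[n+]([O-])c3ccccc3c2C(=O)c2c1c1ccccc1n2Cc1cn(C[C@@H](O)CO)nn1` has not yet been measured. The change from compound 2 is 1-(2,3-dihydroxypropyl)-1H-1,2,3-triazol-4-yl in place of 2-(4-methylpiperazin-1-yl)ethyl on a saturated chain carbon bound to an aromatic nitrogen. In short, 1-(2,3-dihydroxypropyl)-1H-1,2,3-triazol-4-yl replaces 2-(4-methylpiperazin-1-yl)ethyl on a saturated chain carbon bound to an aromatic nitrogen.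

For the measured compounds named here, only one measured step bears on this: a 2.3-fold lower number from compound 1 to compound 2 (0.36 log units; beyond the scatter). That step keeps a piperazine in both compounds, whereas compound 3 has none, so the data do not cover this larger swap. A modest move to a higher number in this assay is expected, with wide uncertainty. The expected change is a 2.5-fold higher number from compound 2 to compound 3 (0.40 log units; beyond the scatter). Compound 3 is estimated at 350 nM, within a range of 100 nM to 1200 nM.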

Compound 3, half-maximal inhibitory concentration: 390 nM
Estimate against measurement, compound 3: 1.1-fold (0.05 log units) below; measured number inside the range.
By their numbers in this assay, from the lowest: compound 2; then compounds 1 and 3 (each within the scatter of the next).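

Replacing 2-(4-methylpiperazin-1-yl)ethyl with 1-(2,3-dihydroxypropyl)-1H-1,2,3-triazol-4-yl on a saturated chain carbon bound to an aromatic nitrogen gives only a modest loss in this assay, seen as a 2.8-fold higher number from compound 2 to compound 3 (0.44 log units; beyond the scatter). The other comparison reads a 1.2-fold higher number from compound 1 to compound 3 (0.09 log units; within the scatter), so among these compounds a piperazine is not required for a number in this range, even though the compound with the lowest number carries one. Nothing available explains why this very different group is tolerated here.

The compounds shown leave open whether the triazole ring or the hydroxyl groups matter more, and how the opposite form of the defined stereocentre behaves. A triazole bearing a plain propyl group, or a simple dimethylamine at the end of the chain, would help separate these questions.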